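The compounds below may be only part of what the source reports. "The series", "measured", "known", "first", "only" and "open" are said of these compounds alone.

In an assay on COS-7 cells for inhibition of patatin-like phospholipase domain-containing protein 2 (Mus musculus), tested at 200 uM (on this read-out lower numbers stand for less inhibition and higher numbers for more inhibition at the one concentration tested (going by the name of the read-out)), compound 1 `CCOC(=O)c1cccc(-c2ccc(OCC)cc2)c1` gives 87%, compound 2 `CCCCOC(=O)c1cccc(-c2ccc(OCC)cc2)c1` gives 61%, and compound 3 `CCOc1ccc(-c2cccc(C(=O)OCC(F)(F)F)c2)cc1` gives 71%. Compound 3 thus stands second highest of the three: its number sits within the scatter of compound 2 and is a number 16 percentage points lower from compound 1 to compound 3 (beyond the scatter). The next compound is compound 4 `CCOc1ccc(-c2cccc(C(=O)OCCOCCOC)c2)cc1`, which differs from compound 3 in one place: (2-methoxyethoxy)methyl in place of trifluoromethyl on a saturated chain carbon bound to an oxygen next to a carbonyl group. Within the data shown here, two measured steps bear on this. Lengthening the ester chain gave a number 26 percentage points lower from compound 1 to compound 2 (beyond the scatter), while exchanging propyl for trifluoromethyl at the same carbon gave a number 10 percentage points higher from compound 2 to compound 3 (within the scatter). The incoming (2-methoxyethoxy)methyl is a longer chain than trifluoromethyl, so the step in this assay is expected to run modestly downward, as the ester-lengthening step did, though an outcome within the scatter cannot be excluded. The expected step is a number 16 percentage points lower from compound 3 to compound 4 (beyond the scatter). For compound 4 in this assay the estimate is 55%, with a likely range from 35% to 75%.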

Compound 4, a percentage reported as inhibition, at one concentration (the size of the read-out at that concentration, not a potency): 43%
Beside the measured number, compound 4's estimate is 12 percentage points above it; the measured number falls inside the stated range.
By their numbers in this assay, from the lowest: compound 4; then compounds 2 and 3 (each within the scatter of the next); then compound 1.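

In this assay, (2-methoxyethoxy)methyl in place of trifluoromethyl gives a number 28 percentage points lower from compound 3 to compound 4 (beyond the scatter), so this position, on a saturated chain carbon bound to an oxygen next to a carbonyl group, responds to a chain carrying hydrogen-bond acceptors as well as to the purely carbon and fluorine chains seen before. Read further along the chain, 2-methoxyethoxy in place of ethyl gives a number 18 percentage points lower from compound 2 to compound 4 (beyond the scatter), and in place of hydrogen gives a number 44 percentage points lower from compound 1 to compound 4 (beyond the scatter), which makes compound 4 the lowest of the four and leaves compound 1, with its ethyl ester, the highest. Nothing available explains this fall.

Going by these compounds, whether the fall follows the length of the chain or the oxygens within it remains open, and a plain heptyl ester would separate the two. On these data alone, how a chain ending in an amine or a carboxylic acid would behave at this position is also open.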